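Compound 2 to compound 3: an aryl exchange

The source may report more compounds than this note shows. Statements on the series, on what has been measured and on what is new or still open speak of the compounds shown alone.

In an ADME assay on PA-1 cells (Homo sapiens) for cytotoxicity, read by MTT assay, with a stated time of 72 h (on this read-out higher numbers stand for weaker inhibition and lower numbers for stronger inhibition), compound 1 `COC(=O)c1cc(C2=C(c3cc(OC)c(OC)c(OC)c3)C(=O)CC2O[SiH2]C(C)(C)C)ccc1OC` reads > 100 ug/mL, which is a limit of the assay and not a number. Among the compounds with values here, compound 2 `COc1cc(C2=C(c3cc(C)c(OC)c(C)c3)C(O[SiH2]C(C)(C)C)CC2=O)cc(OC)c1OC` reads 32 ug/mL, the only actual number so far. Compound 3 `COc1ccc(C2=C(c3cc(OC)c(OC)c(OC)c3)C(=O)CC2O[SiH2]C(C)(C)C)cc1O` has 3-hydroxy-4-methoxyphenyl in place of 4-methoxy-3,5-dimethylphenyl on a double-bonded ring carbon. One measured step involves a group on such a carbon: an at least 3.1-fold lower number from compound 1 to compound 2 (0.49 log units; beyond the scatter), beyond the scatter, with 4-methoxy-3,5-dimethylphenyl replacing 4-methoxy-3-(methoxycarbonyl)phenyl. Within the data shown here, that step shows that this assay can respond to a change there, but no measured compound carries the entering group, so the direction is only weakly supported. A modest move towards stronger inhibition is expected, and the estimated step is a 2.7-fold lower number from compound 2 to compound 3 (0.43 log units; beyond the scatter). For compound 3 the estimate is 12 ug/mL, with an expected range of 2 ug/mL to 70 ug/mL.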

Compound 3, half-maximal inhibitory concentration: 14 ug/mL
Compound 3: the middle estimate sits 1.2-fold (0.07 log units) below what was measured; measured number inside the range.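

Replacing 4-methoxy-3,5-dimethylphenyl with 3-hydroxy-4-methoxyphenyl on a double-bonded ring carbon gives a 2.3-fold lower number from compound 2 to compound 3 (0.36 log units; beyond the scatter) in this assay, so the read-out at this position still moves towards stronger inhibition with a hydroxy-bearing aryl group that has no methyl groups. Hydroxy in place of methoxycarbonyl on an aromatic carbon gives an at least 7.1-fold lower number from compound 1 to compound 3 (0.85 log units; beyond the scatter), the first step shown that exchanges a single substituent on that aromatic ring. The value of compound 1 is a limit, and this step is therefore a bound and not a measured size: the limit of > 100 ug/mL in this assay, at which 1 of the 3 values shown sits.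

The step from compound 2 leaves the entry of hydroxy unseparated from the loss of the two methyl groups. On these data alone, how an amine or a carboxylic acid in place of that hydroxy would read in this assay remains open.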